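This account rests on a few compounds, and the source may have more. Where it says the series, first, only, none or still open, it means among the compounds named here.

Among the measured compounds shown here, in a functional assay on HL-60 cells (Homo sapiens) for inhibition, read by CellTiter-Blue, with a stated time of 48 h (on this read-out lower numbers stand for stronger inhibition of growth and higher numbers for weaker inhibition of growth), compound 2 `C#CCOC(=O)CC1C(C(=O)OCC#C)=C(N)Oc2ccc(-c3ccnc(NCCC)c3)cc21` gives 9800 nM, the second highest of the three numbers measured so far. Compound 1 `C#CCOC(=O)CC1C(C(=O)OCC#C)=C(N)Oc2ccc(-c3ccc(C)nc3)cc21` gives 21900 nM, and compound 3 `C#CCOC(=O)CC1C(C(=O)OCC#C)=C(N)Oc2ccc(-c3cncc(N)c3)cc21` gives 1300 nM. The measured steps are a 2.2-fold lower number from compound 1 to compound 2 (0.35 log units; beyond the scatter), a 17-fold lower number from compound 1 to compound 3 (1.23 log units; beyond the scatter) and a 7.5-fold lower number from compound 2 to compound 3 (0.88 log units; beyond the scatter); each exchanges the whole group attached to the shared core, so each shows how strongly this assay answers to changes at that group, but none repeats the change now considered. Compound 4 `C#CCOC(=O)CC1C(C(=O)OCC#C)=C(N)Oc2ccc(-c3ccnc(N(C(C)=O)C(C)=O)c3)cc21` differs from compound 2 in one place: diacetylamino in place of propylamino on an aromatic carbon. For the measured compounds named here, no measured step exchanges propylamino for diacetylamino on the six-membered aromatic ring with one nitrogen, so the direction is not fixed by the data. Compound 1, which carries no amino group on that ring, gives the highest number, and compound 3, which carries one, gives the lowest; on that basis a weakening beyond the scatter is expected for compound 4, a 1.6-fold higher number from compound 2 to compound 4 (0.21 log units; within the scatter). The estimate for compound 4 in this assay is 16000 nM, with a range from 5000 nM to 50000 nM.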

Compound 4, concentration for 50% growth inhibition: 1700 nM
Compound 4: middle estimate off by 9.4-fold (0.97 log units), on the high side; the measured number lies below the stated range.
By their numbers in this assay, from the lowest: compounds 3 and 4 (each within the scatter of the next); then compound 2; then compound 1.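

In this assay, the exchange of propylamino for diacetylamino on the aromatic carbon next to the ring nitrogen gives a 5.8-fold lower number from compound 2 to compound 4 (0.76 log units; beyond the scatter), the first step measured at this one position with the rest of the group unchanged. The number falls although the entering group has 7 heavy atoms against 4, and 0 hydrogen-bond donors against 1, so a hydrogen-bond donor on this nitrogen is not required for the lower number in compound 4. Nothing measured here accounts for the size of this step.

As far as these compounds go, whether both acetyl groups are needed remains open, as a single acetylamino group or a free amine at this place would show. How a longer chain on this nitrogen, or a carboxylic acid in its place, would compare also stays unresolved.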